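Swapping the Amide Aryl Group in a Sulfone Series

The source may hold more compounds than are shown below. What is called first, only, known or untested is meant among the compounds shown, and "the series" means these compounds.

Compound 3 `Cc1cc(C#N)cc(C)c1Oc1ccnc(S(=O)(=O)CC(=O)Nc2ccccc2Cl)n1` was tested in an ADME assay on MT4 cells (Homo sapiens) for cytotoxicity, read by MTT assay, with a stated time of 4 days (on this read-out lower numbers stand for higher toxicity in this test and higher numbers for lower toxicity in this test), where compound 3 gives 12500 nM, the lower of the two numbers available, although compound 2 `Cc1ccc(NC(=O)CS(=O)(=O)c2nccc(Oc3c(C)cc(C#N)cc3C)n2)cc1C`, which gives 13900 nM, sits within the scatter of it. Compound 1 `Cc1cc(C#N)cc(C)c1Oc1ccnc(SCC(=O)Nc2ccc(C#N)cc2)n1` yields only a limit in this assay, namely > 300000 nM. Compound 4 `Cc1cc(C#N)cc(C)c1Oc1ccnc(S(=O)(=O)CC(=O)Nc2ccc(C#N)cc2)n1` carries 4-cyanophenyl in place of 2-chlorophenyl on an amide-type nitrogen. Among the measured compounds shown here, the one comparable step, a 1.1-fold lower number from compound 2 to compound 3 (0.05 log units; within the scatter), also exchanged the aryl group on that nitrogen and stayed within the scatter, so no shift beyond the scatter is expected in this assay here either. Compound 4 is therefore estimated at 13000 nM, with a range from 5000 nM to 60000 nM, which means an expected step of a 1.0-fold higher number from compound 3 to compound 4 (0.02 log units; within the scatter).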

Compound 4, half-maximal cytotoxic concentration: >= 6010 nM
Compound 4: only a limit was reported; the forecaster's own chance of this, stated with the estimate: 20%; the middle value is on the limit's open side.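

Compound 4 gives only a limit in this assay, >= 6010 nM, and the steps to it from compound 2 and compound 3 cannot be read. The compounds shown leave open whether 4-cyanophenyl on the amide-type nitrogen shifts the number at all.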